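The compounds below may be only part of what the source reports. "The series", "measured", "known", "first", "only" and "open" are said of these compounds alone.

Measured compounds:
compound 1 `O=S(=O)(/C=C/c1ccc(F)cc1)Cc1ccc(Nc2ncnc3ccccc23)cc1` gives 100000 nM in a functional assay on SW-620 cells (Homo sapiens); on this read-out higher numbers stand for weaker inhibition of growth and lower numbers for stronger inhibition of growth.
compound 2 `O=S(=O)(/C=C/c1ccc(Cl)cc1)Cc1ccc(Nc2ncnc3ccccc23)cc1` gives 77000 nM in this assay.
compound 3 `O=S(=O)(/C=C/c1ccc(F)cc1Cl)Cc1ccc(Nc2ncnc3cc(Cl)ccc23)cc1` gives only a limit of the assay, > 100000 nM, in this assay.

Compound 1 and compound 2 share one core and differ in a single spot: fluoro in place of chloro on an aromatic carbon. This change gave a 1.3-fold higher number from compound 2 to compound 1 (0.11 log units; within the scatter). Compound 3 has another core, and the difference between the two cores is not broken down here; its value is a limit, (the limit of > 100000 nM in this assay, at which 1 of the 3 values shown sits).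

Compound 4 `O=S(=O)(/C=C/c1ccc(F)cc1F)Cc1ccc(Nc2ncnc3cc(Cl)ccc23)cc1` has not yet been measured. It differs from compound 3 by the same kind of change: fluoro in place of chloro on an aromatic carbon. The surroundings are not identical, since in compound 1 the new fluoro sits para to a large group, whereas in compound 4 it sits ortho to a large group and meta to a fluoro group.

The step from compound 3 to compound 4 in this assay is expected to be small, a number no higher from compound 3 to compound 4 (the limit leaves the size open), because the earlier step of the same kind was within the scatter, a 1.3-fold higher number from compound 2 to compound 1 (0.11 log units; within the scatter), and because compound 3 reached only a limit, > 100000 nM. Compound 4 is therefore estimated at 100000 nM, most likely again reported as a limit, between 50000 nM and 200000 nM.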

Compound 4, concentration for 50% growth inhibition: > 100000 nM
Compound 4: no number, only a limit; the forecaster's own chance of this, stated with the estimate: 70%; the middle value lies on the limit itself.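

Compound 3 and compound 4 both stop at a limit in this assay rather than giving a number, so no step can be read between them: the limit of > 100000 nM in this assay, at which 2 of the 4 values shown sit.

The compounds shown leave open how far each of the two lies past that limit, and whether fluoro in place of chloro changes growth inhibition on the core of compound 3.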